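This account rests on a few compounds, and the source may have more. Where it says the series, first, only, none or still open, it means among the compounds named here.

Measured compounds, with their results in a functional assay on BGC-823 cells (Homo sapiens) for antiproliferative activity, read by MTT assay, tested at 1 uM; a higher number here means a stronger effect of the compound at the concentration tested, a lower number a weaker effect:

Compound 1 `COc1cc(C2=NN(C(C)=O)C(c3ccccc3C(F)(F)F)O2)cc(OC)c1OC`: 31.8%
Compound 2 `COc1cc(C2=NN(C(C)=O)C(c3ccc(F)c(F)c3)O2)cc(OC)c1OC`: 18.3%
Compound 3 `COc1cc(C2=NN(C(C)=O)C(c3ccc(F)cc3)O2)cc(OC)c1OC`: -0.4%

Compound 3 stands lowest of the three, with compound 2 nearest and compound 1 furthest from it. Compound 4 `COc1cc(C2=NN(C(C)=O)C(c3cccc(OC)c3OC)O2)cc(OC)c1OC` differs from compound 3 by 2,3-dimethoxyphenyl in place of 4-fluorophenyl on a saturated ring carbon. Among the compounds with values here, no measured step exchanges a fluorophenyl for a methoxy-bearing phenyl, so only the steps on the same carbon bear on it: a number 32.2 percentage points lower from compound 1 to compound 3 (beyond the scatter) and a number 18.7 percentage points lower from compound 2 to compound 3 (beyond the scatter). Both show that the 4-fluorophenyl of compound 3 sits at the weak end, and a phenyl carrying two groups, as in compound 1, gave the highest number; a modest rise in this assay is therefore expected, with wide uncertainty. Compound 4 is estimated at 18%, between -5% and 42%, an expected step of a number 18.4 percentage points higher from compound 3 to compound 4 (beyond the scatter).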

Compound 4, a percentage reported as inhibition, at one concentration (the size of the read-out at that concentration, not a potency): 3.8%
Compound 4: the middle estimate sits 14.2 percentage points above what was measured; the range from low to high includes it.
By their numbers in this assay, from the lowest: compounds 3 and 4 (each within the scatter of the next); then compound 2; then compound 1.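

In this assay, the 2,3-dimethoxyphenyl on the saturated ring carbon gives a number 4.2 percentage points higher from compound 3 to compound 4 (within the scatter), so this exchange does not separate it from the 4-fluorophenyl. Against the other two groups, it gives a number 14.5 percentage points lower from compound 2 to compound 4 (beyond the scatter) and a number 28 percentage points lower from compound 1 to compound 4 (beyond the scatter). A dimethoxy-substituted phenyl at this carbon therefore does not reach the level of the 3,4-difluorophenyl or the 2-(trifluoromethyl)phenyl. No available evidence accounts for these differences. From the compounds shown here alone, whether an amine or a carboxylic acid on this phenyl would raise the number remains open.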